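From compound 3 to compound 4: fluoro for methoxy

The compounds below may be only part of what the source reports. "The series", "measured", "known", "first", "only" and "open" are said of these compounds alone.

In a functional assay on HepG2 cells (Homo sapiens) for cytotoxicity, with a stated time of 72 h (a lower number here means that less compound is needed, a higher number that more compound is needed for the effect), compound 1 `C=C[C@@](C)(/C=C/c1ccc(Nc2ccccc2)cc1)CCC=C(C)C` gives > 52000 nM, which is a limit and not a number. Compound 2 `C=C[C@@](C)(/C=C/c1ccc(Nc2ccc(OC)cc2)cc1)CCC=C(C)C` gives > 52000 nM, again a limit. Compound 3 `C=C[C@@](C)(/C=C/c1ccc(Nc2ccc(OC)c(OC)c2)cc1)CCC=C(C)C` gives > 52000 nM, also a limit. Going by the values given here, the series therefore offers no readable number so far, only (the limit of > 52000 nM in this assay, at which 3 of the 3 values shown sit).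

Compound 4 `C=C[C@@](C)(/C=C/c1ccc(Nc2ccc(OC)c(F)c2)cc1)CCC=C(C)C` carries fluoro in place of methoxy on an aromatic carbon, ortho to a methoxy group and meta to a large group (fluoro in place of methoxy on an aromatic carbon).

Two measured changes bear on this, both methoxy in place of hydrogen on an aromatic carbon: a step that the two limits leave unreadable from compound 1 to compound 2 and a step that the two limits leave unreadable from compound 2 to compound 3. Neither has a readable size. The second is the closer precedent, since it concerns the carbon that changes here.

Among the compounds with values here, with a step that the two limits leave unreadable from compound 2 to compound 3 as the only guide, no direction can be assigned, and the expected outcome is a step that the limit leaves unreadable from compound 3 to compound 4. The estimated value for compound 4 is 60000 nM, in a range of 30000 nM to 110000 nM, and a report of only a limit is the expected form of the result.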

Compound 4, half-maximal effective concentration: > 52000 nM
Compound 4 was reported as a limit; the forecaster's own chance of this, stated with the estimate: 85%; the middle value is on the limit's open side.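

In this assay, going by these compounds alone, compound 4 gives > 52000 nM as a limit and not a number, and no step from compound 1, compound 2 or compound 3 to compound 4 can be read. Whether any change on the shared core gives a readable value in this assay stays open for the compounds shown.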